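The source may hold more compounds than are shown below. What is called first, only, known or untested is meant among the compounds shown, and "the series" means these compounds.

In a functional assay on MCF7 cells (Homo sapiens) for antiproliferative activity, read by sulforhodamine B assay, with a stated time of 72 h (a higher number here means a weaker inhibitor, a lower number a stronger inhibitor), compound 1 (`COc1c(OC(C)C)cc2occ(-c3csc4ccccc34)c(=O)c2c1OC(C)C`) gives > 10000 nM, which is a limit and not a number. Compound 2 (`COc1c(OC(C)C)cc2occ(-c3csc4ccccc34)c(=O)c2c1O`) gives > 10000 nM, which is also a limit, so it has no exact potency to start from. Compound 3 (`COc1c(O)cc2occ(-c3csc4ccccc34)c(=O)c2c1O`) differs from compound 2 by one change: hydrogen in place of isopropyl on an oxygen on an aromatic ring. In words, this is isopropoxy to hydroxy, with hydrogen in place of isopropyl on an oxygen on an aromatic ring. The same kind of swap has been measured once, in a step that the two limits leave unreadable from compound 1 to compound 2, and that step offers no size to carry over. The only firm observation is the limit of > 10000 nM in this assay, at which 2 of the 2 values shown sit. Compound 3 is therefore expected to stay in the same region of this assay, and it may again return only a limit. The estimated step is a number no higher from compound 2 to compound 3 (the limit leaves the size open), with no change expected beyond the usual scatter. For compound 3 the estimated value is 10000 nM, with an expected range from 3000 nM to 30000 nM.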

Compound 3, half-maximal inhibitory concentration: > 10000 nM
Compound 3 ended at the assay's limit (the forecaster's own chance of this, stated with the estimate: 65%); the middle value lies on the limit itself.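

No size can be read for the step between compound 2 and compound 3, since in this assay both results are limits and not numbers: the limit of > 10000 nM in this assay, at which 3 of the 3 values shown sit.

The compounds shown leave open whether going from isopropoxy to hydroxy changes potency in this assay at all, and how potent any of the three compounds is.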